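The source may report more compounds than this note shows. Statements on the series, on what has been measured and on what is new or still open speak of the compounds shown alone.

Measured so far: compound 1 `FC(F)(F)c1ccc(CN2CCN(Cc3cc(-c4ccc(OCc5ccccc5)cc4)on3)CC2)cc1` gives 2900 nM in a functional assay on MCF7 cells (Homo sapiens) for antiproliferative activity, read by sulforhodamine B assay, with a stated time of 72 h; a lower number here means a stronger inhibitor, a higher number a weaker inhibitor; compound 2 `Fc1cccc(COc2ccc(-c3cc(CN4CCN(Cc5ccc(C(F)(F)F)cc5)CC4)no3)cc2)c1` gives 2500 nM.

Among the compounds with values here, compound 2 has the lower of the two numbers, but the only step between them, a 1.2-fold lower number from compound 1 to compound 2 (0.06 log units; within the scatter), is within the scatter, so the two compounds cannot be told apart on these data. Compound 3 `COc1ccc(COc2ccc(-c3cc(CN4CCN(Cc5ccc(C(F)(F)F)cc5)CC4)no3)cc2)cc1` has not been measured. It differs from compound 2 by 4-methoxyphenyl in place of 3-fluorophenyl on a saturated chain carbon bound to an oxygen on an aromatic ring. Within the data shown here, the one measured step bears on this change only in part: it shows that adding a fluorine to the benzyl ring left the number essentially unchanged, and removing that fluorine is one part of the present change. Among the measured compounds shown here, the entering methoxy group has no precedent among the measured compounds. On this basis a step no larger than the scatter is expected, with no direction, so compound 3 is estimated at 2800 nM (range 1200 nM to 6500 nM), a step of a 1.1-fold higher number from compound 2 to compound 3 (0.05 log units; within the scatter).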

Compound 3, half-maximal inhibitory concentration: 1300 nM
The estimate for compound 3 lay 2.2-fold (0.33 log units) above the measured number; low and high end bracket the measured number.
By their numbers in this assay, from the lowest: compounds 3, 2 and 1 (each within the scatter of the next, the first and the last beyond it).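

Methoxy in place of hydrogen on the aromatic carbon gives a 2.2-fold lower number from compound 1 to compound 3 (0.35 log units; beyond the scatter) in this assay, the first step in this set that clears the scatter, though only modestly, so this end of the molecule does respond to substitution on the benzyl ring. Against the 3-fluorophenyl of compound 2, however, 4-methoxyphenyl on the same saturated chain carbon gives a 1.9-fold lower number from compound 2 to compound 3 (0.28 log units; within the scatter), so the methoxy compound cannot be separated from the fluoro compound on these data. Nothing given here accounts for either step.

Going by these compounds, it remains open whether the methoxy group itself matters or whether an ethoxy, a hydroxy or an amine on that ring would give a similar number. All three compounds also stay in the same low micromolar range, and whether any change elsewhere on the shared core would move them further is not shown.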